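The source may report more compounds than this note shows. Statements on the series, on what has been measured and on what is new or still open speak of the compounds shown alone.

Measured compounds and their values: compound 1 `CCN(CC)C(=S)SCc1ccc2nc(C)nc(O)c2c1` with 4400 nM, compound 2 `Cc1nc(O)c2cc(CS/C(S)=N/CCCN(C)C)ccc2n1` with 25600 nM, and compound 3 `Cc1nc(O)c2cc(CSC(=S)N3CCCCC3)ccc2n1` with 11300 nM.

In a functional assay on K562 cells (Homo sapiens) for cytotoxicity (a lower number here means a stronger inhibitor, a higher number a weaker inhibitor), compound 3 stands second highest of the three numbers: compound 2 gives a higher number and compound 1 a lower one, both beyond the scatter. Compound 4 `Cc1nc(O)c2cc(CSC(=S)N3CCOCC3)ccc2n1` differs from compound 3 by one change, (morpholin-4-yl in place of piperidin-1-yl on a thiocarbonyl carbon). Among the measured compounds shown here, no measured step swaps these two rings; the only step at this position, a 2.6-fold higher number from compound 1 to compound 3 (0.41 log units; beyond the scatter), was modest. On that basis compound 4 is expected to stay close to compound 3, with a 1.2-fold higher number from compound 3 to compound 4 (0.09 log units; within the scatter) as the estimated step. Compound 4 is therefore estimated at 14000 nM in this assay, with a range from 6000 nM to 32000 nM.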

Compound 4, half-maximal inhibitory concentration: 7200 nM
Compound 4: the middle estimate sits 1.9-fold (0.29 log units) above what was measured; the measured number falls inside the stated range.
By their numbers in this assay, from the lowest: compounds 1, 4 and 3 (each within the scatter of the next, the first and the last beyond it); then compound 2.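

In this assay, the morpholin-4-yl ring brings one hydrogen-bond acceptor that the piperidin-1-yl ring lacks, yet the change stays within the scatter (a 1.6-fold lower number from compound 3 to compound 4 (0.20 log units; within the scatter)). Exchanging the open-chain diethylamino group for morpholin-4-yl on the thiocarbonyl carbon also stays within the scatter (a 1.6-fold higher number from compound 1 to compound 4 (0.21 log units; within the scatter)), so compound 4 cannot be told apart from compound 1 or compound 3, although those two differ beyond the scatter. Nothing at hand gives a cause for these numbers. Still open, as far as these compounds go, is how a piperazine ring, with a second ring nitrogen, or a smaller pyrrolidine ring would behave at this position.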